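This account rests on a few compounds, and the source may have more. Where it says the series, first, only, none or still open, it means among the compounds named here.

Measured so far:
Compound 1 `CNC(=O)CCCCCCCn1nc(-c2ccc3oc(N)nc3c2)c2c(N)ncnc21` gives 12900 nM in a functional assay on HeLa cells (Homo sapiens) for inhibition, read by MTT assay, with a stated time of 72 h; on this read-out lower numbers stand for stronger inhibition and higher numbers for weaker inhibition.
Compound 2 `Nc1nc2cc(-c3nn(CCC(=O)NO)c4ncnc(N)c34)ccc2o1` gives only a limit of the assay, > 150000 nM, in this assay.

For the measured compounds named here, compound 1 stands alone with the only number in this assay; the other value shown, for compound 2, is the limit of > 150000 nM in this assay, at which 1 of the 2 values shown sits. Going by the values given here, the one measured step, an at least 11-fold higher number from compound 1 to compound 2 (1.06 log units; beyond the scatter), concerns the end of the saturated chain and leaves the aromatic group on the core untouched.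

Compound 3 `CNC(=O)CCCCCCCn1nc(-c2cnc3[nH]ccc3c2)c2c(N)ncnc21` differs from compound 1 at a different place: a group of 9 heavy atoms (7 carbon, 2 nitrogen; one five-membered aromatic ring with 1 hetero atom, one six-membered aromatic ring with 1 hetero atom) in place of a group of 10 heavy atoms (7 carbon, 2 nitrogen, 1 oxygen; one five-membered aromatic ring with 2 hetero atoms, one six-membered aromatic ring of carbon only), on an aromatic carbon. The entering group sits on an aromatic carbon of a five-membered aromatic ring with 2 nitrogen, part of a fused system of two rings, next to the ring nitrogen. Among the compounds with values here, no measured step touches this position, so the step from compound 1 to compound 2 gives no guide to its size or direction. In this assay the expected step is therefore no change at the digits printed from compound 1 to compound 3 (within the scatter), with no set direction and nothing beyond the scatter claimed. Compound 3 is estimated at 12900 nM, with a range from 4000 nM to 45000 nM.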

Compound 3, half-maximal inhibitory concentration: 29100 nM
Compound 3: the middle estimate sits 2.3-fold (0.35 log units) below what was measured, within the range that was stated.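

For the compounds shown here, this is the first reading of the position on an aromatic carbon of the five-membered aromatic ring with 2 nitrogen: with the saturated chain left as it is in compound 1, replacing 2-amino-1,3-benzoxazol-5-yl with the group of 9 heavy atoms gives a 2.3-fold higher number from compound 1 to compound 3 (0.35 log units; beyond the scatter) in this assay. The position therefore responds to a change of group, and this exchange moves the number towards weaker inhibition, although the whole group changes at once, including the count of hydrogen-bond acceptors, so the step cannot be assigned to any single atom of it. Nothing shown here accounts for the step.

The compounds shown leave open how a simple phenyl group or a benzoxazole without its amine would read at this position, and so which part of 2-amino-1,3-benzoxazol-5-yl goes with the lower number. They also leave open whether a carboxylic acid or a longer chain at the end of the saturated chain would shift the number, and whether any change at either place would hold with the other place altered.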